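The source may report more compounds than this note shows. Statements on the series, on what has been measured and on what is new or still open speak of the compounds shown alone.

Of the compounds shown here, two built on one shared core have been tested in an assay on HEK293 cells for displacement of a labelled ligand from sodium-dependent dopamine transporter (Homo sapiens), tested at 1 uM; on this read-out lower numbers stand for less inhibition and higher numbers for more inhibition at the one concentration tested (going by the name of the read-out). Compound 1 `CN(C)C[C@@H]1C[C@H]1c1ccc2[nH]cc(C#N)c2c1` gives 39% in this assay. Compound 2 `CN(C)C[C@@H]1CCC[C@H]1c1ccc2[nH]cc(C#N)c2c1` gives 50%, the higher of the two numbers; its gap to compound 1 lies beyond the usual scatter of repeated measurements, so compound 2 stands above compound 1 on the numbers in hand.

Compound 3 `CNC[C@@H]1CCC[C@H]1c1ccc2[nH]cc(C#N)c2c1` has not yet been measured in this assay. It differs from compound 2 in one place: hydrogen in place of methyl on an amine nitrogen. Among the compounds with values here, no pair of measured compounds shows this same change, so nothing measured says how large a step it brings here. The only measured difference, between compound 1 and compound 2, concerns a different part of the molecule and cannot be carried over.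

With that in mind, compound 3 is expected to give about 50%, with a likely range from 30% to 70%. That estimate means an expected step of no change at the digits printed from compound 2 to compound 3 (within the scatter), which is no larger than the scatter, in no particular direction. The measurement will show whether this holds.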

Compound 3, a percentage reported as inhibition, at one concentration (the size of the read-out at that concentration, not a potency): 49%
For compound 3 the middle estimate is 1 percentage points above the measured one; low and high end bracket the measured number.
By their numbers in this assay, from the lowest: compounds 1, 3 and 2 (each within the scatter of the next, the first and the last beyond it).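

Replacing methyl with hydrogen on the amine nitrogen, which turns dimethylamino into methylamino, gives a number 1 percentage points lower from compound 2 to compound 3 (within the scatter) in this assay. Within the data shown here, this is the first measured reading of this change in the set, and it shows that compound 2 and compound 3 cannot be told apart in this read-out at the one concentration tested. For this pair, then, one methyl on the nitrogen can be exchanged for hydrogen without a difference that stands clear of the normal variation between repeated measurements. No measured information is available here to explain this result.

A single pair cannot show whether the same change would give a similar result on the core of compound 1, so what holds for compound 2 and compound 3 cannot yet be extended to other compounds. From the compounds shown here alone, it also remains open how the read-out would respond to other groups at this nitrogen, such as a primary amine with both methyl groups replaced by hydrogen, an ethyl group or a longer chain.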